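From compound 3 to compound 4: removing carbamoyl

The source may hold more compounds than are shown below. What is called first, only, known or untested is meant among the compounds shown, and "the series" means these compounds.

In an ADME assay on Caco-2 cells (Homo sapiens) for permeability, in the apical to basolateral direction (on this read-out lower numbers stand for lower permeability and higher numbers for higher permeability), compound 3 `COC(=O)N1CCN([C@H]2CC[C@H](Nc3ncnn4ccc([C@H](C)CC(N)=O)c34)CC2)CC1` gives 17 10^-6 cm/s, within the scatter of compound 1 `COC(=O)N1CCN([C@H]2CC[C@H](Nc3ncnn4ccc([C@H](C)CC(=O)N(C)C)c34)CC2)CC1` at 18 10^-6 cm/s, while compound 2 `CC(=O)N1CCN([C@H]2CC[C@H](Nc3ncnn4ccc(C(C)C)c34)CC2)CC1` reads higher at 38 10^-6 cm/s, beyond the scatter. Compound 4 `COC(=O)N1CCN([C@H]2CC[C@H](Nc3ncnn4ccc(C(C)C)c34)CC2)CC1` arises from compound 3 through one change: hydrogen in place of carbamoyl on a saturated chain carbon, two bonds along the chain from an aromatic carbon. For the measured compounds named here, the only measured step, a 1.1-fold lower number from compound 1 to compound 3 (0.02 log units; within the scatter), stayed within the scatter and removes no chain, so it bears only weakly here. Compound 4 shares its isopropyl group with compound 2 at 38 10^-6 cm/s, although the two differ elsewhere. A rise in this assay is therefore expected, about the size of the scatter, with an expected step of a 2.1-fold higher number from compound 3 to compound 4 (0.31 log units; beyond the scatter). For compound 4 the estimated value is 35 10^-6 cm/s, with an expected range of 20 10^-6 cm/s to 60 10^-6 cm/s.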

Compound 4, apparent permeability in the Caco-2 assay: 37 10^-6 cm/s
The estimate for compound 4 lay 1.1-fold (0.02 log units) below the measured number, within the range that was stated.
By their numbers in the Caco-2 assay, from the lowest: compounds 3 and 1 (each within the scatter of the next); then compounds 4 and 2 (each within the scatter of the next).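

In the Caco-2 assay, hydrogen in place of carbamoyl gives a 2.2-fold higher number from compound 3 to compound 4 (0.34 log units; beyond the scatter), and hydrogen in place of dimethylcarbamoyl gives a 2.1-fold higher number from compound 1 to compound 4 (0.31 log units; beyond the scatter), so at this saturated chain carbon both amide-bearing compounds read lower than the compound with hydrogen there. Methoxy in place of methyl on a carbonyl carbon, elsewhere in the molecule, gives a 1.0-fold lower number from compound 2 to compound 4 (0.01 log units; within the scatter), so that swap shows no difference beyond the scatter. In a physicochemical assay for lipophilicity, using the shake flask method, at pH 7.4 (a higher number here means a more lipophilic compound, a lower number a more polar compound), compound 3 gives 1.9 and compound 4 gives 3.3 on the same read-out. Removing carbamoyl also makes the compound more lipophilic in the physicochemical assay: the measured distribution coefficient of compound 3, 1.9, and of compound 4, 3.3, a number 1.40 log units higher (beyond the scatter)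

From the compounds shown here alone, whether the rise follows lipophilicity or the loss of the carbamoyl group itself stays open. So does how a carboxylic acid or an amine on this chain would read.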